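Swapping a sulfonamide for a urea on the side chain

A few compounds are considered here, and "the series" means these few. Any claim that something is new, unique, unknown or untested is made for them only; others in the source may bear on it.

Measured compounds and their values:
compound 1, `CCN1CCN(C[C@H]2CN(c3ccc(-n4cc(-c5ccccn5)cn4)c(F)c3)C(=O)O2)CC1`, in an ADME assay on L02 cells (Homo sapiens) for cytotoxicity, read by MTT assay, with a stated time of 48 h; a lower number here means a stronger inhibitor, a higher number a weaker inhibitor: 99 ug/mL
compound 2, `O=C1O[C@@H](Cn2ccnc2)CN1c1ccc(-n2cc(-c3ccccn3)cn2)c(F)c1`, in this assay: 350 ug/mL
compound 3, `CS(=O)(=O)NC[C@H]1CN(c2ccc(-n3cc(-c4ccccn4)cn3)c(F)c2)C(=O)O1`, in this assay: > 400 ug/mL

Compound 3 stands at the weak end of this small set: its value is only a limit of the assay and not a number, as noted in the limit of > 400 ug/mL in this assay, at which 1 of the 3 values shown sits. Compound 4, `CCNC(=O)NC[C@H]1CN(c2ccc(-n3cc(-c4ccccn4)cn3)c(F)c2)C(=O)O1`, differs from compound 3 in one place: ethylcarbamoyl in place of methylsulfonyl on an amine nitrogen.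

Going by the values given here, three measured steps bear on this change. Replacing the ethylpiperazine group by a neutral side group gave a 3.5-fold higher number from compound 1 to compound 2 (0.55 log units; beyond the scatter) and an at least 4.0-fold higher number from compound 1 to compound 3 (0.60 log units; beyond the scatter). Exchanging one neutral side group for another gave an at least 1.1-fold higher number from compound 2 to compound 3 (0.05 log units; that floor lies within the scatter), so that step is too small to read. The change from compound 3 to compound 4 is again an exchange of one neutral side group for another, and therefore a step of about a number no higher from compound 3 to compound 4 (the limit leaves the size open) is expected, with no direction beyond the scatter. Compound 4 is estimated at 400 ug/mL, with a range from 150 ug/mL to 800 ug/mL, and a good chance that this assay will again report only a limit.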

Compound 4, half-maximal inhibitory concentration: > 400 ug/mL
Compound 4: only a limit was reported (the forecaster's own chance of this, stated with the estimate: 60%); the middle value lies on the limit itself.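

In this assay compound 4 gives > 400 ug/mL, which is a limit of the assay and not a number, so the (ethylcarbamoyl)amino group is a second group on this side chain that reaches the limit. Putting it in place of 4-ethylpiperazin-1-yl gives an at least 4.0-fold higher number from compound 1 to compound 4 (0.60 log units; beyond the scatter), whereas putting it in place of 1H-imidazol-1-yl gives an at least 1.1-fold higher number from compound 2 to compound 4 (0.05 log units; that floor lies within the scatter), so only the first comparison shows a direction. Exchanging methylsulfonyl for ethylcarbamoyl on the amine nitrogen cannot be sized, because the step from compound 3 to compound 4 joins two limits, and the same holds for any reading of which of the two is weaker: the limit of > 400 ug/mL in this assay, at which 2 of the 4 values shown sit.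

The compounds shown leave open whether a free amine or a carboxylic acid on the same saturated chain carbon would stay at the limit or give a readable number closer to that of compound 1. Also open, on these data alone, is whether a longer chain in place of the ethyl group of ethylcarbamoyl would bring the value down from the limit.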